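The source may report more compounds than this note shows. Statements on the series, on what has been measured and on what is new or still open speak of the compounds shown alone.

Compound 1 `O=C(OC1(C(=O)Nc2ccc([N+](=O)[O-])cc2)CCCCC1)c1ccc([N+](=O)[O-])cc1` gives 7.7 nM in a functional assay on NFS-60 cells (Mus musculus) for inhibition, read by MTT assay, with a stated time of 72 h; on this read-out higher numbers stand for weaker inhibition and lower numbers for stronger inhibition. Compound 2 `O=C(OC1(C(=O)Nc2ccc([N+](=O)[O-])cc2)CCCCC1)c1ccccc1` gives 766 nM in this assay, the step of a 99-fold higher number from compound 1 to compound 2 (2.00 log units; beyond the scatter) being hydrogen in place of nitro on an aromatic carbon, a large one. Among the compounds with values here, compound 2 thus stands with the higher of the two numbers known. Compound 3 `CCC(=O)OC1(C(=O)Nc2ccc([N+](=O)[O-])cc2)CCCCC1` differs from compound 2 by ethyl in place of phenyl on a carbonyl carbon, benzoyloxy to propanoyloxy. Within the data shown here, no measured step touches the acyl part of the ester; the single step known, a 99-fold higher number from compound 1 to compound 2 (2.00 log units; beyond the scatter), concerns a nitro group and gives no direct guide. Only a modest step is expected, a 2.0-fold higher number from compound 2 to compound 3 (0.29 log units; within the scatter). Compound 3 is therefore estimated at 1500 nM, within 300 nM to 7000 nM.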

Compound 3, half-maximal inhibitory concentration: 6.4 nM
Compound 3: the middle estimate sits 230-fold (2.37 log units) above what was measured; the whole stated range lies above it.
By their numbers in this assay, from the lowest: compounds 3 and 1 (each within the scatter of the next); then compound 2.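

The acyl part of the ester proves to be a position of large effect: ethyl in place of phenyl on the carbonyl carbon gives a 120-fold lower number from compound 2 to compound 3 (2.08 log units; beyond the scatter) in this assay on its own. Ethyl and 4-nitrophenyl cannot be told apart here, with a 1.2-fold lower number from compound 1 to compound 3 (0.08 log units; within the scatter) and so within the scatter, which leaves the unsubstituted phenyl of compound 2 alone with the high number. Nothing measured bears on why this is so.

Open, as far as these compounds go, is whether a longer chain such as butanoyl, or an acyl group carrying an amine, would hold this low level.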